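The compounds below may be only part of what the source reports. "The series", "measured", "known", "first", "only" and "open" are said of these compounds alone.

In a functional assay on HL-60 cells (Homo sapiens) for antiproliferative activity, read by XTT assay, with a stated time of 72 h (on this read-out higher numbers stand for weaker inhibition and lower numbers for stronger inhibition), compound 2 `C=C(C)CC[C@]1(C)C2=CCC[C@](C)(C[C@@H](O)C3=CC(=O)OC3O)[C@H]2CC[C@H]1C` gives 3300 nM and compound 1 `C=C(C)CCC[C@]1(C)C2=CCC[C@](C)(C[C@@H](OC(C)=O)C3=CC(=O)OC3O)[C@H]2CC[C@H]1C` gives 3200 nM. These two numbers lie within the scatter of each other, so compound 2 stands level with compound 1. Compound 3 `C=C(C)CC[C@]1(C)C2=CCC[C@](C)(C[C@@H](OC(C)=O)C3=CC(=O)OC3O)[C@H]2CC[C@H]1C` has acetyl in place of hydrogen on an oxygen on a saturated carbon of compound 2, a change of hydroxy to acetoxy: acetyl in place of hydrogen on an oxygen on a saturated carbon. Among the measured compounds shown here, no step between measured compounds covers this change, so no change beyond the scatter is expected in this assay. The expected step is a 1.1-fold lower number from compound 2 to compound 3 (0.04 log units; within the scatter). For compound 3 the estimated value is 3000 nM, with an expected range from 1300 nM to 7000 nM.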

Compound 3, half-maximal inhibitory concentration: 3300 nM
For compound 3 the middle estimate is 1.1-fold (0.04 log units) below the measured one, and the stated range covers the measured number.
By their numbers in this assay, from the lowest: compounds 1, 2 and 3 (each within the scatter of the next).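

In this assay the change from hydroxy to acetoxy gives no change at the digits printed from compound 2 to compound 3 (within the scatter) on this saturated carbon, so acetyl on this oxygen leaves the number level in this read-out. With acetoxy held fixed, 1-methylethenyl in place of 2-methylprop-2-en-1-yl on the saturated chain carbon gives a 1.0-fold higher number from compound 1 to compound 3 (0.01 log units; within the scatter) as a second reading, so this chain difference also stays within the scatter. Nothing available gives a reason for either step.

As far as these compounds go, whether a benzoyl or aminoacetyl group on this oxygen would also stay level remains open. So does whether a carboxylic acid at the chain end would shift the number.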